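A few compounds are considered here, and "the series" means these few. Any claim that something is new, unique, unknown or untested is made for them only; others in the source may bear on it.

Measured so far in a functional assay on HepG2 cells (Homo sapiens) for inhibition, read by MTT assay, with a stated time of 120 h; on this read-out higher numbers stand for weaker inhibition and lower numbers for stronger inhibition:

Compound 1, `CC(NC(=O)C#Cc1ccc(NC(=O)Nc2cc(C(F)(F)F)ccc2Cl)cc1)c1ccccc1`: 19000 nM
Compound 2, `CC(NC(=O)C#Cc1ccc(NC(=O)Nc2ccc(Cl)c(C(F)(F)F)c2)cc1)c1ccccc1`: 20500 nM
Compound 3, `CC(NC(=O)/C=C/Oc1ccc(NC(=O)Nc2cc(C(F)(F)F)ccc2Cl)cc1)c1ccccc1`: 11900 nM

Compound 1 and compound 2 share the same core and differ in one place: 4-chloro-3-(trifluoromethyl)phenyl in place of 2-chloro-5-(trifluoromethyl)phenyl on an amide-type nitrogen. This exchange gave a 1.1-fold higher number from compound 1 to compound 2 (0.03 log units; within the scatter), so the two sit side by side. Compound 3 is built on another core than compound 1; the difference between the two cores is not broken down here. Its value and those of compound 1 and compound 2 all lie within the usual scatter of one another, so no ordering among the three can be read from these numbers.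

Compound 4, `CC(NC(=O)/C=C/Oc1ccc(NC(=O)Nc2ccc(Cl)c(C(F)(F)F)c2)cc1)c1ccccc1`, has not yet been measured. For the measured compounds named here, it differs from compound 3 by 4-chloro-3-(trifluoromethyl)phenyl in place of 2-chloro-5-(trifluoromethyl)phenyl on an amide-type nitrogen, which is the same change as the one from compound 1 to compound 2, made at the same kind of place. The step from compound 3 to compound 4 in this assay is therefore expected to be small, about a 1.1-fold higher number from compound 3 to compound 4 (0.04 log units; within the scatter), resting on the step of a 1.1-fold higher number from compound 1 to compound 2 (0.03 log units; within the scatter). For compound 4 the expected value is 13000 nM, most likely between 6000 nM and 28000 nM.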

Compound 4, half-maximal inhibitory concentration: 14100 nM
For compound 4 the middle estimate is 1.1-fold (0.04 log units) below the measured one, within the range that was stated.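

In this assay, putting 4-chloro-3-(trifluoromethyl)phenyl in place of 2-chloro-5-(trifluoromethyl)phenyl on an amide-type nitrogen gave a 1.2-fold higher number from compound 3 to compound 4 (0.07 log units; within the scatter) on the core of compound 3. Set beside the same exchange on the core of compound 1, the two steps agree, so in this pair of cores the exchange carried over without a readable shift: the same change on two cores in this assay, a 1.1-fold higher number (0.03 log units; within the scatter) from compound 1 to compound 2 and a 1.2-fold higher number (0.07 log units; within the scatter) from compound 3 to compound 4, 1.1-fold (0.04 log units) apart, within the scatter of two such steps. This does not show that the two groups are interchangeable on every core in the series, because two small steps on two cores are all there is, and steps this small cannot show whether the exchange has any real effect at all.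

The compounds shown leave open how the read-out responds to a larger change on this ring, since both groups carry the same chlorine and trifluoromethyl substituents. From the compounds shown here alone, a nitrile or a carboxylic acid in place of the trifluoromethyl would test that, and it remains unknown whether such a change would carry from one core to the other.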